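The source may report more compounds than this note shows. Statements on the series, on what has been measured and on what is new or still open speak of the compounds shown alone.

Compound 1 `COc1ccc(Cc2cc(-c3ccc(C)cc3)nn(CC(=O)Nc3ccc(Br)cc3)c2=O)cc1` gives > 50000 nM in a functional assay on HL-60 cells (Homo sapiens), read by calcium flux (a higher number here means that more compound is needed for the effect, a lower number that less compound is needed), a limit of the measurement. Compound 2 `COc1ccc(Cc2cc(Cc3ccccc3)nn(CC(=O)Nc3ccc(Br)cc3)c2=O)cc1` gives > 50000 nM in this assay, again a limit. Compound 3 `COc1cc(Cc2cc(C)nn(CC(=O)Nc3ccc(Br)cc3)c2=O)cc(OC)c1` gives > 50000 nM in this assay, also a limit.

Within the data shown here, compound 3 therefore stands at the limit of > 50000 nM in this assay, at which 3 of the 3 values shown sit, so no number is known for it, only that more compound than the assay can test would be needed. Compound 4 `Cc1cc(Cc2ccc(C(N)=O)cc2)c(=O)n(CC(=O)Nc2ccc(Br)cc2)n1` differs from it by 4-carbamoylphenyl in place of 3,5-dimethoxyphenyl on a saturated chain carbon bound to an aromatic carbon. Among the measured compounds shown here, the only measured step, a step that the two limits leave unreadable from compound 1 to compound 2, cannot be read because both ends are limits, and no measured compound carries a carbamoyl group, so nothing measured bears directly on this change. The expected step of a number no higher from compound 3 to compound 4 (the limit leaves the size open) is therefore none that can be seen. Compound 4 is estimated at 50000 nM, between 10000 nM and 200000 nM, most likely again reported as a limit.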

Compound 4, half-maximal effective concentration: > 50000 nM
Compound 4: a limit, no number; the forecaster's own chance of this, stated with the estimate: 75%; the middle value lies on the limit itself.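

Compound 3 and compound 4 both give a limit rather than a number, so the step between them cannot be read. Which structural change would give a measurable value in this assay remains open.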